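A few compounds are considered here, and "the series" means these few. Any claim that something is new, unique, unknown or untested is made for them only; others in the source may bear on it.

In a functional assay on HeLa cells (Homo sapiens), read by colorimetric assay, with a stated time of 72 h (a lower number here means that less compound is needed, a higher number that more compound is needed for the effect), compound 1 `CCOC(=O)c1cc(CBr)nn1[C@@H]1O[C@H](COC(C)=O)[C@@H](OC(C)=O)[C@H]1OC(C)=O` gives 2.5 ug/mL. Compound 2 `CCOC(=O)c1cc(CBr)n([C@@H]2O[C@H](COC(C)=O)[C@@H](OC(C)=O)[C@H](OC(C)=O)[C@H]2OC(C)=O)n1` gives 6 ug/mL, a higher number beyond the scatter of compound 1. Compound 3 `CC(=O)OC[C@H]1O[C@@H](n2nc(CBr)cc2C(N)=O)[C@H](OC(C)=O)[C@@H](OC(C)=O)[C@@H]1OC(C)=O` gives 4 ug/mL, which lies within the scatter of compound 1, so compound 1 stands clearly apart from only one of the two.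

Compound 4 `CC(=O)OC[C@H]1O[C@@H](n2nc(CBr)cc2C(N)=O)[C@H](OC(C)=O)[C@@H]1OC(C)=O` keeps the rest of compound 1 and changes one group: amino in place of ethoxy on a carbonyl carbon. This places amino in place of ethoxy on a carbonyl carbon, turning ethoxycarbonyl into carbamoyl.

For the measured compounds named here, no pair of measured compounds shows this change alone, so the expectation rests on thin evidence. Compound 3 also carries carbamoyl and gives 4 ug/mL, although it differs from compound 1 in other ways too. On that basis, no step beyond the scatter is expected in this assay. The expected step of a 1.2-fold higher number from compound 1 to compound 4 (0.08 log units; within the scatter) is small and stays within the scatter.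

For compound 4 the estimated value is 3 ug/mL, with an expected range of 1.3 ug/mL to 7 ug/mL.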

Compound 4, concentration for half-maximal effect: 2 ug/mL
Estimate against measurement, compound 4: 1.5-fold (0.18 log units) above; the range from low to high includes it.
By their numbers in this assay, from the lowest: compounds 4, 1, 3 and 2 (each within the scatter of the next, the first and the last beyond it).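

In this assay, putting amino in place of ethoxy on a carbonyl carbon gives a 1.3-fold lower number from compound 1 to compound 4 (0.10 log units; within the scatter). Compound 1 and compound 4 are the first pair shown to differ in this one place alone, and they show that ethoxycarbonyl and carbamoyl cannot be told apart by this read-out, even though amino has fewer heavy atoms than ethoxy and brings a hydrogen-bond donor that ethoxy lacks. Nothing at hand gives a reason for this result.

Only these two groups have been compared at this place, so the result cannot be extended to other groups. A free carboxylic acid, a methylamino group on the carbonyl carbon or a longer ester chain such as butoxy could still give a different number.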